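Triazole-linked bis(benzyloxy)butenolides: antiproliferative readout on MCF7 cells

A few compounds are considered here, and "the series" means these few. Any claim that something is new, unique, unknown or untested is made for them only; others in the source may bear on it.

Measured compounds, with their values in a functional assay on MCF7 cells (Homo sapiens) for antiproliferative activity, read by MTT assay, with a stated time of 72 h; a higher number here means a weaker inhibitor, a lower number a stronger inhibitor:
- compound 1 `COc1ccccc1-c1cn(C[C@H](O)[C@H]2OC(=O)C(OCc3ccccc3)=C2OCc2ccccc2)nn1` — in this assay compound 1 gives > 100000 nM, which is a limit of the assay and not a number.
- compound 2 `O=C1O/C(=C\Cn2cc(-c3cc(C(F)(F)F)cc(C(F)(F)F)c3)nn2)C(OCc2ccccc2)=C1OCc1ccccc1` — in this assay compound 2 gives > 100000 nM, again a limit.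
- compound 3 `COc1ccccc1-c1cn(C/C=C2\OC(=O)C(OCc3ccccc3)=C2OCc2ccccc2)nn1` — in this assay compound 3 gives > 100000 nM, again a limit.

Compound 1 therefore stands at the upper edge of what this assay reports, without a measured number of its own. The same holds across the small set examined: the limit of > 100000 nM in this assay, at which 3 of the 3 values shown sit. Within the data shown here, no pair of measured compounds differs in one place only, so no measured step is available, and nothing in these three values separates one compound from another.

Compound 4 `O=C1O[C@H]([C@@H](O)Cn2cc(-c3cc(F)cc(F)c3)nn2)C(OCc2ccccc2)=C1OCc1ccccc1` is the next candidate. It differs from compound 1 by 3,5-difluorophenyl in place of 2-methoxyphenyl on an aromatic carbon, in words: 3,5-difluorophenyl in place of 2-methoxyphenyl on an aromatic carbon.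

With every measured value sitting at the limit, the step of a number no higher from compound 1 to compound 4 (the limit leaves the size open) is expected to be none beyond the scatter, in neither direction. In this assay compound 4 is expected to give 100000 nM, in the range 40000 nM to 300000 nM, most probably reported again as a limit.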

Compound 4, half-maximal inhibitory concentration: 27700 nM
Compound 4: the middle estimate sits 3.6-fold (0.56 log units) above what was measured, and the stated range ends above it.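

In this assay, among these compounds, 3,5-difluorophenyl in place of 2-methoxyphenyl on an aromatic carbon of the five-membered aromatic ring with 3 nitrogen gives an at least 3.6-fold lower number from compound 1 to compound 4 (0.55 log units; beyond the scatter), the first step that can be read at all. Compound 1 gives > 100000 nM, which is a limit of the assay and not a number, so the step has a lower bound on its size and no upper one. Among the compounds shown here, compound 4 gives 27700 nM and is the first compound here with a number of its own, which shows that the aryl group at this position can move the read-out, something the earlier compounds could not show.

The change removes the methoxy group and brings in two fluorine atoms in a single step, so this one pair cannot say which part of it carries the difference, and a phenyl ring with one fluorine would be needed to separate them. How an amine or a carboxylic acid on that aryl ring would read also stays open, and the series offers little to compare it with, since most of the set gives no number: the limit of > 100000 nM in this assay, at which 3 of the 4 values shown sit.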